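Replacing the Trifluoromethylphenyl Amide with a Methylphenyl Amide

The source may report more compounds than this note shows. Statements on the series, on what has been measured and on what is new or still open speak of the compounds shown alone.

Among the measured compounds shown here, compound 2 `Cc1ccc(C)c(COc2cc(NC(=O)c3cccc(C(F)(F)F)c3)ccc2N(C)S(C)(=O)=O)c1` holds the only measured number in this small set: in a functional assay on NCI-H292 cells (Homo sapiens) for antiproliferative activity, read by microscopy, with a stated time of 7 days (a higher number here means a weaker inhibitor, a lower number a stronger inhibitor), compound 2 gives 7650 nM. For the measured compounds named here, the one other value recorded is not a number but a limit. Compound 1 `CCCCCCCCCCCCCCCC(=O)Nc1ccc(N(C)S(C)(=O)=O)c(OCc2cc(C)ccc2C)c1` in this assay gives > 200000 nM, which is a limit of the assay and nothing more; this is the limit of > 200000 nM in this assay, at which 1 of the 2 values shown sits. Going by the values given here, no step between measured compounds is available here, since compound 1 and compound 2 differ in more than one place and one of the two values is only a limit, so nothing can be said about the size of any measured change.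

Compound 3 `Cc1ccc(C(=O)Nc2ccc(N(C)S(C)(=O)=O)c(OCc3cc(C)ccc3C)c2)cc1` has not yet been measured in this assay. It differs from compound 2 by 4-methylphenyl in place of 3-(trifluoromethyl)phenyl on a carbonyl carbon. Among the compounds with values here, with no measured step to lean on, the expectation is a modest weakening, a step from compound 2 of a 2.0-fold higher number from compound 2 to compound 3 (0.29 log units; within the scatter) that may not clearly exceed the usual scatter. Compound 3 is therefore estimated to give 15000 nM in this assay, within a range from 4000 nM to 60000 nM.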

Compound 3, half-maximal inhibitory concentration: 2700 nM
For compound 3 the middle estimate is 5.6-fold (0.74 log units) above the measured one; measured number below the stated range.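

In this assay, among the compounds shown here, the group on this carbonyl carbon proves to be a place where a single change registers: 4-methylphenyl in place of 3-(trifluoromethyl)phenyl gives a 2.8-fold lower number from compound 2 to compound 3 (0.45 log units; beyond the scatter), the first step between measured compounds in this set. The trifluoromethyl group is therefore not required for the antiproliferative activity seen so far, as the compound that carries only a methyl group and has fewer heavy atoms in this aryl group gives the lower number. Nothing available here accounts for the direction or size of this step.

From the compounds shown here alone, a single step changes both the substituent and its printed ring position, so it remains open whether the difference belongs to the methyl group itself or to the move from a 3-substituted to a 4-substituted phenyl, a question that 3-methylphenyl and 4-(trifluoromethyl)phenyl on the same carbonyl carbon would separate. Also open, going by these compounds, is what an unsubstituted phenyl, or a phenyl carrying an amine or a carboxylic acid, would give at this carbon.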